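A few compounds are considered here, and "the series" means these few. Any claim that something is new, unique, unknown or untested is made for them only; others in the source may bear on it.

Three thiazolidinone analogues bearing a halogenated benzylidene arm have been measured for growth inhibition of a lung carcinoma cell line. Compound 1 `O=C1NC(=S)/C(=C/c2ccc(Cl)cc2)S1` carries a single chloro substituent, compound 2 `O=C1NC(=S)/C(=C/c2cc(Cl)cc(Cl)c2Cl)S1` three chlorines, and compound 3 `O=C1NC(=S)/C(=C/c2ccccc2Br)S1` a single bromine. In a functional assay on NCI-H292 cells (Homo sapiens) for cytotoxicity, read by MTT assay, with a stated time of 72 h, tested at 10 ug/mL (a lower number here means less inhibition of growth, a higher number more inhibition of growth at the concentration tested), compound 1 gives 41.4%. Compound 2 gives 40.5% in this assay, and compound 3 gives 36.9%. Compound 1 thus holds the highest of the three numbers, yet the gap to compound 2 and even the larger gap to compound 3 both fall within the scatter of repeated measurements, so the three cannot be ranked against one another.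

Compound 4 `O=C1NC(=S)/C(=C/c2ccc(Br)cc2)S1` is the next analogue to be tested. It differs from compound 1 only by bromo in place of chloro on an aromatic carbon. Going by the values given here, no measured pair in this set differs in a single place, so no step between measured compounds is available to guide the expectation. Given that all three measured numbers sit close together, the step from compound 1 to compound 4 in this assay is expected to be small, a number 0.4 percentage points lower from compound 1 to compound 4 (within the scatter), in no particular direction beyond the scatter. Compound 4 is therefore estimated to give 41%, within a range of 30% to 52%.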

Compound 4, percent growth inhibition at one concentration: 36.5%
Compound 4: middle estimate off by 4.5 percentage points, on the high side, and the stated range covers the measured number.
By their numbers in this assay, from the lowest: compounds 4, 3, 2 and 1 (each within the scatter of the next).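

Going by these compounds alone, with bromo in place of chloro on an aromatic carbon, para to a group of 8 heavy atoms, this assay records a number 4.9 percentage points lower from compound 1 to compound 4 (within the scatter) as the only comparison in this set that changes a single place. Within the data shown here, at this position, then, the exchange of one halogen for the other, which alters no ring, no charge and no count of hydrogen-bond donors or acceptors, gives no step that can be told from the scatter. No measurement at hand bears on this result, so nothing can be said about what lies behind it.

As far as these compounds go, whether a larger departure from halogen, such as an amine, a methoxy group or a carboxylic acid on this same carbon, would move growth inhibition beyond the scatter stays open. So does the effect of any change on the shared core itself.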